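Fluoro for methoxy on the aryl-substituted core

A few compounds are considered here, and "the series" means these few. Any claim that something is new, unique, unknown or untested is made for them only; others in the source may bear on it.

Measured so far:
compound 1 `CCCC[C@@]1(CO)NC[C@H](O)[C@H]1O`, 220 nM
compound 2 `COc1cccc([C@]2(CO)NC[C@@H](O)[C@@H]2O)c1`, 52000 nM
compound 3 `COc1ccc([C@@]2(CO)NC[C@H](O)[C@H]2O)cc1OC`, 60000 nM

In an assay on isolated protein for inhibition of lysosomal alpha-glucosidase (Rattus norvegicus), read by colorimetric assay (a lower number here means a stronger inhibitor, a higher number a weaker inhibitor), compound 2 stands second highest of the three numbers. Its nearest neighbour is compound 3, whose number sits within the scatter of it, so no order between the two can be stated. The furthest is compound 1, which gives a far lower number beyond the scatter, the butyl substituent on the shared core standing well apart from the two aryl groups.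

Compound 4 `OC[C@@]1(c2cccc(F)c2)NC[C@@H](O)[C@@H]1O` differs from compound 2 by fluoro in place of methoxy on an aromatic carbon. Going by the values given here, no step between measured compounds covers this change; both aryl analogues sit close together at the high end of this assay. The step from compound 2 to compound 4 is expected to be small, if anything slightly lower, as a 1.3-fold lower number from compound 2 to compound 4 (0.11 log units; within the scatter). Compound 4 is estimated at 40000 nM, with a range from 12000 nM to 130000 nM.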

Compound 4, half-maximal inhibitory concentration: 216000 nM
For compound 4 the middle estimate is 5.4-fold (0.73 log units) below the measured one; the measured number lies above the stated range.
By their numbers in this assay, from the lowest: compound 1; then compounds 2 and 3 (each within the scatter of the next); then compound 4.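

Working notes: in this assay, fluoro in place of methoxy gives a 4.2-fold higher number from compound 2 to compound 4 (0.62 log units; beyond the scatter) and so a weaker inhibitor, the first single-place step in the series. This aromatic carbon, meta to the group of 9 heavy atoms, therefore responds to the change, even though compound 2 already sits at the high end of the numbers. Nothing at hand accounts for the step.

Going by these compounds, whether methoxy itself helps or fluoro alone costs remains open. A hydroxy, an amine or a plain methyl at this place would separate the two readings.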